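Cytotoxicity notes on the aminocyclohexanol series

The compounds below may be only part of what the source reports. "The series", "measured", "known", "first", "only" and "open" are said of these compounds alone.

Compound 1 `CC1(C)C[C@H](O)C[C@](C)(CNc2ccccc2)C1` gives 37000 nM in an ADME assay on MDCK cells (Canis lupus familiaris) for cytotoxicity, read by MTT assay, with a stated time of 3 days; a higher number here means that more compound is tolerated, a lower number that less compound is tolerated. Compound 2 `CC1(C)C[C@H](O)C[C@](C)(CNc2cccc(C#N)c2)C1` gives 46900 nM in this assay, a step of a 1.3-fold higher number from compound 1 to compound 2 (0.10 log units; within the scatter). Compound 3 `CC1(C)C[C@H](O)C[C@](C)(CNc2cccc(S(N)(=O)=O)c2)C1` reaches the upper limit of this assay and is reported only as > 100000 nM. Compound 3 therefore sits at the limit of > 100000 nM in this assay, at which 1 of the 3 values shown sits, and both an at least 2.7-fold higher number from compound 1 to compound 3 (0.43 log units; beyond the scatter) and an at least 2.1-fold higher number from compound 2 to compound 3 (0.32 log units; beyond the scatter) run toward that limit. Compound 4 `CC1(C)C[C@H](O)C[C@](C)(CNc2cc(C(F)(F)F)cc(S(N)(=O)=O)c2)C1` differs from compound 3 by trifluoromethyl in place of hydrogen on an aromatic carbon. Among the compounds with values here, no measured step introduces a trifluoromethyl, so the two steps ending at compound 3 bear only indirectly: they show the sulfamoyl-bearing compound already outside the range, and the added group is not expected to move this assay beyond the scatter. Compound 4 is expected to stay near the limit, with a number no higher from compound 3 to compound 4 (the limit leaves the size open) giving an estimate of 100000 nM (range 40000 nM to 250000 nM).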

Compound 4, half-maximal cytotoxic concentration: 19500 nM
Estimate against measurement, compound 4: 5.1-fold (0.71 log units) above, outside the stated range (below it).
By their numbers in this assay, from the lowest: compounds 4, 1 and 2 (each within the scatter of the next, the first and the last beyond it). At a limit, above all of these: compound 3.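

Trifluoromethyl on this aromatic carbon, meta to a sulfamoyl group, gives the only downward step shown in this assay: an at least 5.1-fold lower number from compound 3 to compound 4 (0.70 log units; beyond the scatter). Placed here, it brings the sulfamoyl-bearing compound back to a measured value, whereas the earlier steps to compound 3 all ran upward. On these data alone, the true size of the step stays open, since the value of compound 3 is a limit and not a number: the limit of > 100000 nM in this assay, at which 1 of the 4 values shown sits.

As far as these compounds go, whether a chlorine or a methyl at this place would give a similar step stays open. So does the size of the trifluoromethyl step without the sulfamoyl group.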